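The compounds below may be only part of what the source reports. "The series", "measured", "known", "first", "only" and "open" are said of these compounds alone.

Three compounds have been examined in an ADME assay on cells (Erythrocyte, Homo sapiens) for activation, read by hemolysis, with a stated time of 30 min, tested at 2.5 mM; a higher number here means a stronger effect of the compound at the concentration tested, a lower number a weaker effect. Compound 3 `COc1ccc(-c2ccc(-c3ccc(C(=N)N)s3)s2)cc1` gives 41%. Compound 1 `N=C(N)c1ccc(-c2ccc(-c3ccccc3)s2)s1`, which carries hydrogen in place of methoxy on an aromatic carbon, gives 15.3% in this assay, a step of a number 25.7 percentage points lower from compound 3 to compound 1 (beyond the scatter). Compound 2 `COc1ccc(-c2ccc(-c3ccc(C(=N)N)o3)o2)cc1` gives 8.1% in this assay; against compound 1 the gap is within the scatter, against compound 3 it is beyond it. The difference between the core of compound 2 and the core of compound 3 is not broken down here.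

Compound 4 `N=C(N)c1ccc(-c2ccc(-c3ccccc3)o2)o1` has not yet been measured. It differs from compound 2 by the change (hydrogen in place of methoxy on an aromatic carbon), the same change that leads from compound 3 to compound 1. On that single precedent the expected step is a number 4.1 percentage points lower from compound 2 to compound 4 (within the scatter), smaller than the earlier one, because compound 2 already gives 8.1% and a percentage of hemolysis cannot fall far below that. Compound 4 is therefore estimated at 4%, with a likely span from 0% to 15%.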

Compound 4, a percentage reported as activity, at one concentration (the size of the read-out at that concentration, not a potency): 7%
Beside the measured number, compound 4's estimate is 3 percentage points below it, and the stated range covers the measured number.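

In this assay, putting hydrogen in place of methoxy on the core of compound 2 gives a step that is a number 1.1 percentage points lower from compound 2 to compound 4 (within the scatter). The same change therefore does not carry over at the same size from one core to the other: the same change on two cores in this assay, a number 25.7 percentage points lower (beyond the scatter) from compound 3 to compound 1 and a number 1.1 percentage points lower (within the scatter) from compound 2 to compound 4, 24.6 percentage points apart, beyond the scatter of two such steps. Among these compounds, this shows that, in these two pairs, the core matters to how much the change moves hemolysis, but with only two pairs it gives no rule for other cores and does not show why the steps differ.

The compounds shown leave open how other groups on that aromatic carbon, such as a fluorine, a hydroxyl or an amine, would behave on either core. They also leave open whether a longer chain, such as ethoxy in place of methoxy, would raise the reading on the core of compound 3 and leave it unmoved on the core of compound 2.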